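Benzodioxinyl for chloroethoxyphenyl on the oxanyl pyrrolidine core

This account rests on a few compounds, and the source may have more. Where it says the series, first, only, none or still open, it means among the compounds named here.

Compound 1 `CCOc1ccc(-c2cc3ncn([C@H]4CCN(C(=O)N(C)[C@H]5CCN(C)C5)C4)c(=O)c3s2)c(Cl)c1` is measured in an assay on isolated protein for binding affinity to melanin-concentrating hormone receptor 1 (Homo sapiens) (on this read-out higher numbers stand for weaker inhibition and lower numbers for stronger inhibition), at 26 nM. Compound 2 `CN1CC[C@H](N(C)C(=O)N2CC[C@H](n3cnc4cc(-c5ccc6c(c5)OCCO6)sc4c3=O)C2)C1` carries a different aromatic group on the shared core; in this assay compound 2 gives 143 nM. The change between them is 2,3-dihydro-1,4-benzodioxin-6-yl in place of 2-chloro-4-ethoxyphenyl on an aromatic carbon and it made a 5.5-fold higher number from compound 1 to compound 2 (0.74 log units; beyond the scatter). Compound 3 `CCOc1ccc(-c2cc3ncn([C@H]4CCN(C(=O)N(C)[C@H]5CCN(C6CCOCC6)C5)C4)c(=O)c3s2)c(Cl)c1` differs from compound 1 in the group on the pyrrolidine nitrogen, (oxan-4-yl in place of methyl on an amine nitrogen in a ring), and in this assay compound 3 gives 14 nM; that step is a 1.9-fold lower number from compound 1 to compound 3 (0.27 log units; within the scatter). Compound 4 `CN(C(=O)N1CC[C@H](n2cnc3cc(-c4ccc5c(c4)OCCO5)sc3c2=O)C1)[C@H]1CCN(C2CCOCC2)C1` has not yet been measured in this assay. It differs from compound 3 by 2,3-dihydro-1,4-benzodioxin-6-yl in place of 2-chloro-4-ethoxyphenyl on an aromatic carbon, which is the same change that leads from compound 1 to compound 2; the place reads the same word for word in both pairs, so the change is the same, and it occurs twice among the four compounds. The two cores differ as told by oxan-4-yl in place of methyl on an amine nitrogen in a ring. From compound 3 to compound 4 a step of a 5.4-fold higher number from compound 3 to compound 4 (0.73 log units; beyond the scatter) is expected, matching the size of a 5.5-fold higher number from compound 1 to compound 2 (0.74 log units; beyond the scatter). Going by the values given here, this rests on compound 1 at 26 nM and compound 3 at 14 nM lying within the scatter of each other, which gives no sign that the core change alters the response to the aromatic swap; with only one measured instance of the change the range is kept wide. Compound 4 is expected to give 75 nM in this assay, between 35 nM and 160 nM.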

Compound 4, inhibition constant: 45 nM
Estimate against measurement, compound 4: 1.7-fold (0.22 log units) above; measured number inside the range.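

In this assay the swap to 2,3-dihydro-1,4-benzodioxin-6-yl on the oxan-4-yl core gives a 3.2-fold higher number from compound 3 to compound 4 (0.51 log units; beyond the scatter), the same direction as on the core of compound 1, and the two steps cannot be told apart: the same change on two cores in this assay, a 5.5-fold higher number (0.74 log units; beyond the scatter) from compound 1 to compound 2 and a 3.2-fold higher number (0.51 log units; beyond the scatter) from compound 3 to compound 4, 1.7-fold (0.23 log units) apart, within the scatter of two such steps. Read the other way, the oxan-4-yl for methyl change gives a 3.2-fold lower number from compound 2 to compound 4 (0.50 log units; beyond the scatter) on the benzodioxinyl side, and its two instances cannot be told apart either, although only this one lies beyond the scatter: the same change on two cores in this assay, a 1.9-fold lower number (0.27 log units; within the scatter) from compound 1 to compound 3 and a 3.2-fold lower number (0.50 log units; beyond the scatter) from compound 2 to compound 4, 1.7-fold (0.23 log units) apart, within the scatter of two such steps. Within these four compounds the two changes therefore carry from one core to the other without a detectable interaction, but this is a single set of two cores and two aromatic groups, so it does not show that the aromatic swap would carry over to other groups on the amine nitrogen, and it gives no reason for the higher numbers.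

It remains open which part of the 2-chloro-4-ethoxyphenyl group accounts for the difference, since a phenyl bearing only the ethoxy group or only the chlorine would separate the two. Also open, as far as these compounds go, is whether the same agreement holds with a cyclohexyl or an acetyl on the amine nitrogen in place of oxan-4-yl.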